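Moving the Chlorine Around the Benzyl Ring

A few compounds are considered here, and "the series" means these few. Any claim that something is new, unique, unknown or untested is made for them only; others in the source may bear on it.

Compound 1 `CCCSc1nc(N/N=C(\C)c2ccccc2O)c2nnn(Cc3ccc(Cl)cc3)c2n1` is tested in a functional assay on ECa-109 cells (Homo sapiens) for antiproliferative activity, read by MTT assay, with a stated time of 72 h (on this read-out lower numbers stand for stronger inhibition and higher numbers for weaker inhibition), where compound 1 gives 11200 nM. Within the data shown here, that is the only plain number in hand. Compound 2 `CCCSc1nc(N/N=C/c2cccnc2)c2nnn(Cc3ccccc3)c2n1` returns only > 64000 nM in this assay, a limit of the method and not a measured number. Compound 3 `CCCSc1nc(N/N=C(\C)c2ccccc2O)c2nnn(Cc3ccccc3Cl)c2n1` is the untested partner of compound 1, and differs from it by 2-chlorophenyl in place of 4-chlorophenyl on a saturated chain carbon bound to an aromatic nitrogen. Among the measured compounds shown here, no measured pair shows this change, so the expected shift is small, within the scatter or slightly toward weaker inhibition. Compound 3 is expected at 14000 nM, within 5000 nM to 45000 nM. The step of a 1.3-fold higher number from compound 1 to compound 3 (0.10 log units; within the scatter) is the expected size of that move.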

Compound 3, half-maximal inhibitory concentration: > 64000 nM
Compound 3 ended at the assay's limit; the forecaster's own chance of this, stated with the estimate: 15%; middle value at least 4.5-fold (0.66 log units) from the limit.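

Moving the chlorine on this saturated chain carbon bound to an aromatic nitrogen, from 4-chlorophenyl to 2-chlorophenyl, is not a neutral change: in this assay it gives an at least 5.7-fold higher number from compound 1 to compound 3 (0.75 log units; beyond the scatter). The two compounds hold the same atoms, so the place of the chlorine alone separates them. The full size of the step cannot be read because compound 3 stands at a limit and not at a measured number: the limit of > 64000 nM in this assay, at which 2 of the 3 values shown sit.

Still open, going by these compounds, is whether a 4-fluorophenyl or a 4-methoxyphenyl group at this place would keep the inhibition of compound 1. Whether the loss follows the same course on a different core is also unknown.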